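Replacing a Chlorophenyl Group with Methoxy

This account rests on a few compounds, and the source may have more. Where it says the series, first, only, none or still open, it means among the compounds named here.

Compound 3 `Cc1cc(-c2ccc(Cl)cc2)c(S(C)(=O)=O)cc1C(=O)N=C(N)N` gives 45 nM in a functional assay for inhibition of sodium/hydrogen exchanger (Oryctolagus cuniculus) (a higher number here means a weaker inhibitor, a lower number a stronger inhibitor), the lowest of the three numbers shown. Compound 1 `Cc1c(C(=O)N=C(N)N)cc(S(C)(=O)=O)c(C)c1C` gives 55 nM in this assay, and compound 2 `Cc1cc(Br)c(C(=O)N=C(N)N)cc1S(C)(=O)=O` gives 70 nM; both of these values lie within the scatter of compound 3, so no order among the three can be claimed. Compound 4 `COc1cc(C)c(C(=O)N=C(N)N)cc1S(C)(=O)=O` has not yet been measured. It differs from compound 3 in one place: methoxy in place of 4-chlorophenyl on an aromatic carbon. Among the measured compounds shown here, no step between measured compounds isolates this change, and the three measured compounds give values within the scatter of one another. Compound 4 is therefore expected to stay close, with a step of a 1.6-fold higher number from compound 3 to compound 4 (0.19 log units; within the scatter) not beyond the scatter. Compound 4 is estimated at 70 nM, within 30 nM to 170 nM.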

Compound 4, half-maximal inhibitory concentration: 16 nM
Beside the measured number, compound 4's estimate is 4.4-fold (0.64 log units) above it, and the stated range ends above it.
By their numbers in this assay, from the lowest: compound 4; then compounds 3, 1 and 2 (each within the scatter of the next).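

Placed ortho to a methylsulfonyl group, this substituent can clearly shift the result: in this assay, methoxy in place of 4-chlorophenyl gives a 2.8-fold lower number from compound 3 to compound 4 (0.45 log units; beyond the scatter). The 4-chlorophenyl ring is therefore not needed at this position for strong inhibition. Nothing measured here explains the step.

The compounds shown cannot separate losing the ring from gaining the oxygen of methoxy. On these data alone, whether a plain ethyl chain, with no oxygen, or an amine would match methoxy at this position remains open.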